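A few compounds are considered here, and "the series" means these few. Any claim that something is new, unique, unknown or untested is made for them only; others in the source may bear on it.

In an in vivo ADME assay on the whole organism for pharmacokinetics, with Rattus norvegicus as the target (a higher number here means that more of the compound sits outside the plasma, a lower number that more of the compound stays in the plasma), compound 1 (`COc1ccc2c(c1)CC(c1nc3ccc(-c4ccnc(N)n4)cc3[nH]1)CO2`) gives 0.9 L/kg and compound 2 (`Nc1nccc(-c2ccc3nc(C4COc5c(cccc5C(=O)NC5CC5)C4)[nH]c3c2)n1`) gives 1.4 L/kg. Within the data shown here, these two values lie within the scatter of each other, so compound 1 does not stand apart from compound 2 on the numbers so far.

Compound 3 (`CN(C)CCCNC(=O)c1ccc2c(c1)CC(c1nc3ccc(-c4ccnc(N)n4)cc3[nH]1)CO2`) carries (3-(dimethylamino)propyl)carbamoyl in place of methoxy on an aromatic carbon of the core of compound 1: (3-(dimethylamino)propyl)carbamoyl in place of methoxy on an aromatic carbon. Among the measured compounds shown here, the series holds no measured pair that differs in one place, so no direct precedent exists for the size of this step, and the expectation rests on the structural change alone. A rise beyond the scatter in this assay is expected, estimated as a 3.9-fold higher number from compound 1 to compound 3 (0.59 log units; beyond the scatter). For compound 3, the estimated value is 3.5 L/kg, with an expected range of 1.5 L/kg to 8 L/kg.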

Compound 3, volume of distribution at steady state: 4.6 L/kg
Compound 3: middle estimate off by 1.3-fold (0.12 log units), on the low side, and the stated range covers the measured number.
By their numbers in this assay, from the lowest: compounds 1 and 2 (each within the scatter of the next); then compound 3.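

In this assay, the aromatic carbon that carries methoxy in compound 1 tolerates a much larger substituent, and the number responds to the change. Placing (3-(dimethylamino)propyl)carbamoyl there gives a 5.1-fold higher number from compound 1 to compound 3 (0.71 log units; beyond the scatter) and is the first step in the series that can be read between compounds differing in one place. No measurement shown bears on the origin of this step, so it remains an observation without an assigned cause.

Still open, from the compounds shown here alone, is which part of the new group carries the step: a simple carboxamide, or an amide with a shorter chain ending in the same dimethylamino group, would separate the amide from the chain and its terminal amine. Also open, going by these compounds, is whether a longer chain or a cyclic amine such as morpholine at this carbon would move the number further.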